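The source may report more compounds than this note shows. Statements on the series, on what has been measured and on what is new or still open speak of the compounds shown alone.

Measured in a functional assay on HepG2 cells (Homo sapiens) for cytotoxicity, read by MTT assay, with a stated time of 72 h; on this read-out lower numbers stand for stronger inhibition and higher numbers for weaker inhibition:
- Compound 1 `CC(C)n1c(Nc2ccccc2)nc2cnc(Nc3ccc(N4CCN(C)CC4)cc3)nc21`: > 5000 nM, a limit of the assay.
- Compound 2 `CN1CCN(c2ccc(Nc3ncc4nc(Nc5cccc([N+](=O)[O-])c5)n(C5CCCC5)c4n3)cc2)CC1`: > 5000 nM, a limit of the assay.
- Compound 3 `C#Cc1cccc(Nc2nc3cnc(Nc4ccc(N5CCN(C)CC5)cc4)nc3n2C2CCCC2)c1`: 4900 nM.

Going by the values given here, compound 3 at 4900 nM holds the only actual number in this assay. The other two values are limits.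

Next in the series is compound 4 `Cc1cccc(Nc2nc3cnc(Nc4ccc(N5CCN(C)CC5)cc4)nc3n2C2CCCC2)c1`, with methyl in place of ethynyl on an aromatic carbon, meta to a large group (methyl in place of ethynyl on an aromatic carbon).

Among the compounds with values here, one measured step bears on this change, ethynyl in place of nitro on an aromatic carbon: an at least 1.0-fold lower number from compound 2 to compound 3 (0.00 log units; that floor lies within the scatter). That step gives only a floor and shows no change beyond the scatter. It therefore offers no evidence of sensitivity to the group at this place, though one step with a limit at one end is thin support. The other reference point is the limit of > 5000 nM in this assay, at which 2 of the 3 values shown sit.

The expected result, a 1.0-fold higher number from compound 3 to compound 4 (0.01 log units; within the scatter), is no shift beyond the scatter in this assay, with no direction favoured. Within the data shown here, a reported limit rather than a number would be no surprise for this compound.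

For compound 4 the estimated value is 5000 nM, with an expected range from 2500 nM to 10000 nM.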

Compound 4, half-maximal inhibitory concentration: 4700 nM
Beside the measured number, compound 4's estimate is 1.1-fold (0.03 log units) above it, within the range that was stated.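

In this assay, methyl in place of ethynyl on an aromatic carbon can now be read between two actual numbers rather than against a limit: a 1.0-fold lower number from compound 3 to compound 4 (0.02 log units; within the scatter). Methyl in place of nitro can be read only as a floor, an at least 1.0-fold lower number from compound 2 to compound 4 (0.02 log units; that floor lies within the scatter), so that step sets no size for the change and shows nothing beyond the scatter. The 3-ethynylphenyl and 3-methylphenyl groups both give actual numbers, so this position now has two groups that cannot be told apart in this assay, though neither number stands clear of the edge of what the assay reports: the limit of > 5000 nM in this assay, at which 2 of the 4 values shown sit.

On these data alone, whether an amine or a carboxylic acid on this aromatic carbon, or a longer chain in place of methyl, would move the number beyond the scatter stays open. The three groups compared here, nitro, ethynyl and methyl, also leave open whether any group at this place can give a number well away from that edge, so the position cannot yet be called insensitive to change.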